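The source may report more compounds than this note shows. Statements on the series, on what has been measured and on what is new or still open speak of the compounds shown alone.

Compound 1, `CC[C@H](C)[C@H](NC(=O)c1cccc(Cn2ccnc2)c1)c1nn[nH]n1`, in an assay on HEK293 cells for displacement of a labelled ligand from Type-2 angiotensin II receptor (Homo sapiens), tested at 10 uM; on this read-out lower numbers stand for a weaker effect and higher numbers for a stronger effect at the one concentration tested: "not active" (no number reported). Compound 2, `CC[C@H](C)[C@H](NC(=O)c1cccc(Cn2ccnc2)c1)C(=O)NNS(=O)(=O)c1ccc(C)cc1`: 20%. Compound 3, `CC[C@H](C)[C@H](NC(=O)c1cccc(Cn2ccnc2)c1)C(N)=O`: "not active" (no number reported).

Compound 3 thus stands without a single number in this assay; compound 1 also carries only a verbal result, and compound 2 alone has a figure. The unmeasured compound 4, `CC[C@H](C)[C@H](NC(=O)c1cccc(Cn2ccnc2)c1)C(=O)NO`, is reached from compound 3 by one change: hydroxy in place of hydrogen on an amide-type nitrogen. Among the compounds with values here, no measured pair shows what this change does, so the size of the step is open. Since compound 3 reads "not active" (no number reported), a clear signal in compound 4 would be a real departure; the expected step is no more than the scatter, in either direction. Compound 4 is estimated to give 8% in this assay, within 0% to 25%.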

Compound 4, a percentage reported as inhibition, at one concentration (the size of the read-out at that concentration, not a potency): 4%
For compound 4 the middle estimate is 4 percentage points above the measured one; low and high end bracket the measured number.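

In this assay, hydroxy in place of ((4-methylphenyl)sulfonyl)amino on the amide-type nitrogen gives a number 16 percentage points lower from compound 2 to compound 4 (beyond the scatter) and so does not keep the signal of compound 2. The step from compound 3 cannot be read, as compound 3 has only the verbal result "not active" (no number reported) and no number. Nothing available explains these results.

Still open, on these data alone, is whether a methyl on this nitrogen, or a carboxylic acid in place of the hydroxycarbamoyl, would read differently from compound 4. Also open, as far as these compounds go, is how much of the signal of compound 2 depends on its 4-methylphenyl group.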